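The source may hold more compounds than are shown below. What is called first, only, known or untested is meant among the compounds shown, and "the series" means these compounds.

Measured in an ADME assay on HFF cells (Homo sapiens) for cytotoxicity, with a stated time of 8 days; on this read-out lower numbers stand for higher toxicity in this test and higher numbers for lower toxicity in this test:
Compound 1 `Nc1nc(OCC(F)(F)F)c2ncn(/C=C3/CC3(CO)CO)c2n1`: > 300000 nM, a limit
Compound 2 `CC(C)CNc1nc(N)nc2c1ncn2/C=C1/CC1(CO)CO`: > 300000 nM, a limit

Compound 2 thus has no exact value in this assay, only a limit. Compound 3 `CCCOc1nc(N)nc2c1ncn2/C=C1/CC1(CO)CO` carries propoxy in place of isobutylamino on an aromatic carbon. Within the data shown here, the one measured step bearing on this change, also on an aromatic carbon, is a step that the two limits leave unreadable from compound 1 to compound 2. Its size cannot be read, so it gives no measured size to carry over. No step beyond the scatter is expected for compound 3 because of the limit of > 300000 nM in this assay, at which 2 of the 2 values shown sit. The expected change is a number no higher from compound 2 to compound 3 (the limit leaves the size open). Compound 3 is estimated at 300000 nM, within an expected range of 120000 nM to 300000 nM.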

Compound 3, half-maximal cytotoxic concentration: > 300000 nM
Compound 3 was reported as a limit (the forecaster's own chance of this, stated with the estimate: 85%); the middle value lies on the limit itself.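

Among these compounds, compound 1, compound 2 and compound 3 all sit at the same limit in this assay, so no step between them can be read. The compounds shown leave open whether their true cytotoxic concentrations differ at all.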